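A Sulfur-Linked Heterocycle Swap Measured for Cytotoxicity

The source may report more compounds than this note shows. Statements on the series, on what has been measured and on what is new or still open speak of the compounds shown alone.

Compound 1 `Cc1nnc(SCc2cc(=O)c3ccccc3o2)s1` gives in a functional assay on HeLa cells (Homo sapiens) for cytotoxicity, read by MTT assay, with a stated time of 72 h (a higher number here means a weaker inhibitor, a lower number a stronger inhibitor), only a limit, > 25000 nM. Compound 2 `Cc1cc(O)cc2oc(=O)cc(CSc3nc4ccccc4[nH]3)c12` gives in this assay only a limit, > 25000 nM. Compound 3 `Nc1nc(SCc2coc3ccccc3c2=O)n[nH]1` gives in this assay only a limit, > 25000 nM.

Within the data shown here, compound 3 therefore stands where every value shown stands, at the limit of > 25000 nM in this assay, at which 3 of the 3 values shown sit, and no step between measured compounds can be counted. Compound 4 `Nc1nnc(SCc2coc3ccccc3c2=O)s1` differs from compound 3 in one place: 5-amino-1,3,4-thiadiazol-2-yl in place of 5-amino-1H-1,2,4-triazol-3-yl on a sulfur. Compound 1, which also carries a thiadiazole on its sulfur, shows the same limit as compound 3. No step beyond the scatter is expected in this assay for this change, in either direction, so compound 4 is expected to sit at the limit as well. The estimate for compound 4 is 30000 nM, with a range from 10000 nM to 100000 nM, and the expected step is a step that the limit leaves unreadable from compound 3 to compound 4.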

Compound 4, half-maximal inhibitory concentration: > 25000 nM
Compound 4: a limit, no number; the forecaster's own chance of this, stated with the estimate: 85%; the middle value is on the limit's open side.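

Compound 3 and compound 4 both sit at a limit, so no step can be read between them: the limit of > 25000 nM in this assay, at which 4 of the 4 values shown sit. The compounds shown leave open whether any group on the sulfur gives a readable number in this assay.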